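Pyridyl-to-phenyl ether change in the piperidine series

The source may report more compounds than this note shows. Statements on the series, on what has been measured and on what is new or still open speak of the compounds shown alone.

Of the compounds shown here, three of the shared core have been measured in an ADME assay on PBMC cells (Homo sapiens) for cytotoxicity; a higher number here means that more compound is tolerated, a lower number that less compound is tolerated. Compound 1 `Cc1cccc(OC(c2ccc(Br)cc2)C2CCN(C(C)CCNC(=O)c3c(Cl)cncc3Cl)CC2)n1` gives 6500 nM; compound 2 `CC(CCNC(=O)c1c(Cl)cncc1Cl)N1CCC(C(Oc2cc(Cl)ccn2)c2ccc(C(F)(F)F)cc2)CC1` gives 4260 nM; compound 3 `CC(CCNC(=O)c1c(Cl)cncc1Cl)N1CCC(C(Oc2cccnc2)c2ccc(Br)cc2)CC1` gives 32500 nM. Compound 2 stands at the low end of these numbers: its gap to compound 1 lies within the scatter, while compound 3 stands beyond the scatter above it. Among the compounds with values here, the only measured step that varies the same position is a 5.0-fold higher number from compound 1 to compound 3 (0.70 log units; beyond the scatter), a swap of one pyridyl for another.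

Compound 4 `CC(CCNC(=O)c1c(Cl)cncc1Cl)N1CCC(C(Oc2cccc(Cl)c2)c2ccc(C(F)(F)F)cc2)CC1` differs from compound 2 by 3-chlorophenyl in place of 4-chloropyridin-2-yl on an oxygen on a saturated carbon. Within the data shown here, no measured pair changes a pyridyl to a phenyl ether at this place, so the available step shows only that this position can move the number in this assay by a modest amount. Among the measured compounds shown here, with no direct precedent, no step beyond the scatter is expected, though the range is left wide. The expected value for compound 4 is 5000 nM, within 2000 nM to 13000 nM, meaning an estimated step of a 1.2-fold higher number from compound 2 to compound 4 (0.07 log units; within the scatter).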

Compound 4, half-maximal cytotoxic concentration: 8100 nM
Compound 4: middle estimate off by 1.6-fold (0.21 log units), on the low side; measured number inside the range.
By their numbers in this assay, from the lowest: compounds 2, 1 and 4 (each within the scatter of the next); then compound 3.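

In this assay, the change from a pyridyl ether to a phenyl ether at this place gives a 1.9-fold higher number from compound 2 to compound 4 (0.28 log units; within the scatter), so a ring of carbon only, with no hydrogen-bond acceptor in the group, is accepted here without a step beyond the scatter. Together with a 5.0-fold higher number from compound 1 to compound 3 (0.70 log units; beyond the scatter), this shows that the position does not move the number by a step beyond the scatter with every change of ring: one of the two measured changes does, and the other does not. No measurement at hand offers an explanation for this result.

Still open, as far as these compounds go, is whether pyridin-3-yl on this oxygen would give a comparable step alongside the trifluoromethyl group of compound 2. Also open, from the compounds shown here alone, is how this assay would respond to an amine or a carboxylic acid in place of the chlorine on the 3-chlorophenyl group.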